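Expected Tolerance of Compound 3 in Cytotoxicity Testing

The compounds below may be only part of what the source reports. "The series", "measured", "known", "first", "only" and "open" are said of these compounds alone.

Measured compounds:
compound 1 `Cc1ccc(-c2c3c(nc(C)c2[C@H](OC(C)(C)C)C(=O)O)CCN(C(=O)NCc2ccccc2)C3)cc1` reaches only the assay limit, > 40000 nM
compound 2 `Cc1ccccc1CCCN1CCc2nc(C)c([C@H](OC(C)(C)C)C(=O)O)c(-c3cc(F)c4c(c3C)CCCO4)c2C1` reaches only the assay limit, > 40000 nM

In an ADME assay on MT2 cells (Homo sapiens) for cytotoxicity, read by XTT assay, with a stated time of 4 days (a lower number here means that less compound is tolerated, a higher number that more compound is tolerated), compound 1 gives a limit rather than a number, and compound 2 gives the same kind of limit. Compound 1 therefore stands where every shown value stands: the limit of > 40000 nM in this assay, at which 2 of the 2 values shown sit. Compound 3 `Cc1ccc(-c2c3c(nc(C)c2[C@H](OC(C)(C)C)C(=O)O)CCN(C(=O)CCc2ccccc2)C3)cc1` differs from compound 1 in one place: phenethyl in place of benzylamino on a carbonyl carbon, that is, benzylcarbamoyl becomes phenethylcarbonyl on a carbonyl carbon whose other neighbour is an amide-type nitrogen in a ring. For the measured compounds named here, no step between two measured compounds is available, so the size of this change cannot be read from data. Still, with both shown values at the limit, compound 3 is expected to sit there too, a step from compound 1 of a number no higher from compound 1 to compound 3 (the limit leaves the size open), none beyond the usual scatter. Compound 3 is estimated at 40000 nM, between 20000 nM and 100000 nM, most likely again reported only as a limit.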

Compound 3, half-maximal cytotoxic concentration: > 40000 nM
Compound 3 ended at the assay's limit (the forecaster's own chance of this, stated with the estimate: 85%); the middle value lies on the limit itself.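

Compound 1 and compound 3 both stop at the assay's limit, so no step can be read for phenethyl in place of benzylamino. The compounds shown leave open what concentration of any of them harms the cells, and whether any structural change shifts it: the limit of > 40000 nM in this assay, at which 3 of the 3 values shown sit.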